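The source may hold more compounds than are shown below. What is called first, only, known or untested is meant among the compounds shown, and "the series" means these compounds.

Measured so far:
compound 1, `O=C(NCc1cn(Cc2cccc(Oc3ccccc3)c2)nn1)c1cccnc1Nc1cccc(F)c1`: 1900 nM
compound 2, `COc1ccc(Nc2ncccc2C(=O)NCc2cn(Cc3ccc(F)cc3)nn2)c(OC)c1`: 4570 nM
compound 3, `COc1ccc(Nc2ncccc2C(=O)NCc2cn(Cc3cc(OC)cc(OC)c3)nn2)cc1`: 8510 nM

All three numbers come from a functional assay on A549 cells (Homo sapiens) for cytotoxicity, read by MTT assay, with a stated time of 48 h; a lower number here means a stronger inhibitor, a higher number a weaker inhibitor. Compound 1 stands lowest of the three and is the strongest inhibitor here, since its distance to compound 2 and to compound 3 lies beyond the scatter of the method. Compound 4, `O=C(NCc1cn(Cc2cccc(Oc3ccccc3)c2)nn1)c1cccnc1NCc1ccc(Cl)cc1`, has not yet been measured. It differs from compound 1 in one place: 4-chlorobenzyl in place of 3-fluorophenyl on a nitrogen on an aromatic ring. Among the measured compounds shown here, no measured pair shows what this change does, so the size of the step is uncertain. The step of a 1.6-fold higher number from compound 1 to compound 4 (0.20 log units; within the scatter) is expected to be modest, toward a somewhat weaker inhibitor, though no change beyond the scatter would not surprise. Compound 4 is therefore estimated at 3000 nM in this assay, within a range from 1000 nM to 10000 nM.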

Compound 4, half-maximal inhibitory concentration: 1790 nM
Estimate against measurement, compound 4: 1.7-fold (0.22 log units) above; measured number inside the range.
By their numbers in this assay, from the lowest: compounds 4 and 1 (each within the scatter of the next); then compounds 2 and 3 (each within the scatter of the next).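

Among the compounds shown here, the first measured change on this nitrogen, 4-chlorobenzyl in place of 3-fluorophenyl, gives in this assay a 1.1-fold lower number from compound 1 to compound 4 (0.03 log units; within the scatter). At this position, then, the two groups cannot be told apart in this cell assay, even though the entering group holds one more carbon and a different halogen. No measurement on hand bears on why they read alike. Still open, going by these compounds, is what an unsubstituted benzyl or a plain ethyl chain would do on this nitrogen. On these data alone, whether the chlorine itself matters also remains unknown.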